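The compounds below may be only part of what the source reports. "The series", "measured", "known", "first", "only" and "open" are said of these compounds alone.

Compound 1 `Cc1cc(Oc2ccc(CC3SC(=O)NC3=O)cc2)nc(C(F)(F)F)c1` gives 688 nM
Compound 2 `Cc1ccc(C)c(Oc2ccc(CC3SC(=O)NC3=O)cc2)c1` gives 238 nM
Compound 3 `Cc1ccccc1Oc1ccc(CC2SC(=O)NC2=O)cc1` gives 124 nM

All three compounds were tested in a functional assay for agonist activity at Free fatty acid receptor 1 (Homo sapiens), read by FLIPR, in the presence of a further agent that is not named here; on this read-out higher numbers stand for an effect only at larger amounts of compound and lower numbers for an effect already at smaller amounts. Compound 1 returns the highest number of the three; the difference between the core of compound 1 and the core of compound 2 is not broken down here, so only their values can be set side by side. Compound 2 and compound 3 share a core and differ in one place, (hydrogen in place of methyl on an aromatic carbon). That change produced a 1.9-fold lower number from compound 2 to compound 3 (0.28 log units; within the scatter).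

Compound 4 `O=C1NC(=O)C(Cc2ccc(Oc3cccc(C(F)(F)F)n3)cc2)S1` has not yet been measured in this assay. It stands to compound 1 as compound 3 stands to compound 2, the change being (hydrogen in place of methyl on an aromatic carbon). Among the compounds with values here, it is the same kind of change as the one from compound 2 to compound 3, but not the same: in the measured pair the carbon sits in a six-membered aromatic ring of carbon only, para to a methyl group, whereas in compound 1 it sits in a six-membered aromatic ring with one nitrogen, meta to a trifluoromethyl group and opposite the ring nitrogen.

Within the data shown here, on the single precedent, the step from compound 1 to compound 4 is expected to be a 1.4-fold lower number from compound 1 to compound 4 (0.16 log units; within the scatter), close in size to a 1.9-fold lower number from compound 2 to compound 3 (0.28 log units; within the scatter), because compound 1 gives 688 nM and the earlier removal of the methyl moved the number only within the scatter. Compound 4 is therefore estimated at 480 nM, with a likely range from 200 nM to 1400 nM.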

Compound 4, half-maximal effective concentration: 1640 nM
For compound 4 the middle estimate is 3.4-fold (0.53 log units) below the measured one; the measured number lies above the stated range.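

In this assay, replacing the methyl with hydrogen on the core of compound 1 gave a 2.4-fold higher number from compound 1 to compound 4 (0.38 log units; beyond the scatter), a step beyond the scatter, though only a modest one. Set side by side, the two instances of this one change do not agree: the same change on two cores in this assay, a 1.9-fold lower number (0.28 log units; within the scatter) from compound 2 to compound 3 and a 2.4-fold higher number (0.38 log units; beyond the scatter) from compound 1 to compound 4, 4.6-fold (0.66 log units) apart, beyond the scatter of two such steps. This shows that, among the compounds shown, the result of this replacement on one core cannot simply be carried over to the other, but with only one pair on each core it does not show which difference between the two cores or between the two places of the methyl lies behind the gap, nor whether either step would hold on a further core.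

The compounds shown leave open whether the methyl on the core of compound 1 is specifically required, or whether an ethyl group, a chlorine atom or a methoxy group at the same place would serve equally well. They also leave open how much the trifluoromethyl group shared by compound 1 and compound 4 contributes, which a nitrile or a chlorine atom in its place on either core could begin to answer.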